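The compounds below may be only part of what the source reports. "The series", "measured", "known", "first", "only" and "open" are said of these compounds alone.

Measured so far:
Compound 1 `Cc1c(OCc2ccccc2)c(=O)ccn1CCNc1ccnc2cc(Cl)ccc12` gives 54000 nM in an ADME assay on KB cells (Homo sapiens) for cytotoxicity, read by resazurin assay, with a stated time of 72 h; a lower number here means a stronger inhibitor, a higher number a weaker inhibitor.
Compound 2 `Cc1c(OCc2ccccc2)c(=O)ccn1CCCNc1ccnc2cc(Cl)ccc12` gives 67000 nM in this assay.
Compound 3 `CCc1c(OCc2ccccc2)c(=O)ccn1CCNc1ccnc2cc(Cl)ccc12` gives 51000 nM in this assay.

Compound 3 differs from compound 1 by methyl in place of hydrogen on a saturated chain carbon bound to an aromatic carbon. That change gave a 1.1-fold lower number from compound 1 to compound 3 (0.02 log units; within the scatter). Compound 2 carries a different core from compound 1; the difference between the two cores is not broken down here, and the values of compound 1 and compound 2 lie within the scatter of each other. Compound 4 `CCc1c(OCc2ccccc2)c(=O)ccn1CCCNc1ccnc2cc(Cl)ccc12` differs from compound 2 by methyl in place of hydrogen on a saturated chain carbon bound to an aromatic carbon, the same change at the same place as between compound 1 and compound 3, now made on the core of compound 2. Because the earlier step of a 1.1-fold lower number from compound 1 to compound 3 (0.02 log units; within the scatter) stayed within the scatter, the step from compound 2 to compound 4 is expected to be a 1.1-fold lower number from compound 2 to compound 4 (0.03 log units; within the scatter). The value estimated for compound 4 in this assay is 62000 nM, with an expected range from 35000 nM to 110000 nM.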

Compound 4, half-maximal inhibitory concentration: 15000 nM
Compound 4: middle estimate off by 4.1-fold (0.62 log units), on the high side; the measured number lies below the stated range.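

Methyl in place of hydrogen on a saturated chain carbon bound to an aromatic carbon does not carry over at one size between these two cores in this assay: the same change on two cores in this assay, a 1.1-fold lower number (0.02 log units; within the scatter) from compound 1 to compound 3 and a 4.5-fold lower number (0.65 log units; beyond the scatter) from compound 2 to compound 4, 4.2-fold (0.63 log units) apart, beyond the scatter of two such steps.
The new step is a 4.5-fold lower number from compound 2 to compound 4 (0.65 log units; beyond the scatter), so the change is a real one on the core of compound 2, while on the core of compound 1 it stays within the scatter.
With a single pair on each core, this shows that the step depends on the core for these compounds, but it gives no rule for the series and no reason for the gap.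

Still open, going by these compounds, is whether propyl or cyclopropyl in place of the ethyl of compound 4 goes further on the core of compound 2. Also open, on these data alone, is how either group behaves on the core of compound 1.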